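The source may hold more compounds than are shown below. What is called first, only, known or untested is meant among the compounds shown, and "the series" means these compounds.

In a functional assay on DU-145 cells (Homo sapiens) for antiproliferative activity, read by sulforhodamine B assay, with a stated time of 72 h (a higher number here means a weaker inhibitor, a lower number a stronger inhibitor), the measured compounds give:

- Compound 1 `O=C1CS/C(=N/Nc2nncc3ccccc23)N1c1ccccc1`: 97 nM
- Compound 2 `CCN1C(=O)CS/C1=N/Nc1nncc2ccccc12`: 86 nM
- Compound 3 `Cc1cc(C)nc(NS(=O)(=O)c2ccc(Nc3nncc4ccccc34)cc2)n1`: 7.8 nM

Compound 3 has the lowest number of the three, beyond the scatter from both others. Compound 4 `NS(=O)(=O)c1ccc(Nc2nncc3ccccc23)cc1` departs from it by hydrogen in place of 4,6-dimethylpyrimidin-2-yl on a sulfonamide nitrogen. Among the compounds with values here, the one measured step, a 1.1-fold lower number from compound 1 to compound 2 (0.05 log units; within the scatter), concerns ethyl in place of phenyl on an amide-type nitrogen in a ring, so it bears only weakly on this change. Within the data shown here, no measured step removes this group. Compound 3 at 7.8 nM already sits lowest, so a higher number seems likelier than a lower one. The expected step is a 3.2-fold higher number from compound 3 to compound 4 (0.51 log units; beyond the scatter), and it is uncertain. For compound 4 the estimate is 25 nM, with an expected range of 5 nM to 120 nM.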

Compound 4, half-maximal inhibitory concentration: 14 nM
For compound 4 the middle estimate is 1.8-fold (0.25 log units) above the measured one; the measured number falls inside the stated range.
By their numbers in this assay, from the lowest: compounds 3 and 4 (each within the scatter of the next); then compounds 2 and 1 (each within the scatter of the next).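

In this assay the 4,6-dimethylpyrimidin-2-yl group on the sulfonamide nitrogen gives way to hydrogen with a change that stays within the scatter (a 1.8-fold higher number from compound 3 to compound 4 (0.25 log units; within the scatter)). Within the data shown here, the low number of compound 3 therefore does not depend on this group, and the unsubstituted sulfonamide of compound 4 keeps it, which no earlier step could show for this position. Nothing given here accounts for this result. The compounds shown leave open how a methyl, an acetyl or a plain phenyl on that nitrogen would read, and whether a carboxylic acid could replace the whole sulfonamide.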